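This account rests on a few compounds, and the source may have more. Where it says the series, first, only, none or still open, it means among the compounds named here.

In a functional assay on HepG2 cells (Homo sapiens) for cytotoxicity, read by WST assay, with a stated time of 24 h (on this read-out higher numbers stand for lower toxicity in this test and lower numbers for higher toxicity in this test), compound 1 `CCCCCCCc1cc(-c2ccc3cc(C(=O)O)ccc3c2)ccc1O` gives 1.89 ug/mL and compound 2 `CCCCCCCCCc1cc(-c2ccc3cc(C(=O)O)ccc3c2)ccc1O` gives 1.73 ug/mL so the two stand level within the scatter. Among the measured compounds shown here, the only measured step is a 1.1-fold lower number from compound 1 to compound 2 (0.04 log units; within the scatter) and it touches the saturated chain alone. Compound 3 `CCCCCCCc1cc(-c2ccc3cc(CO)ccc3c2)ccc1O` keeps the chain of compound 1 and differs elsewhere, with hydroxymethyl in place of carboxy on an aromatic carbon. For the measured compounds named here, no measured pair tests this change, so the chain step offers no direct guide to its size or direction. Without evidence for a direction, no step beyond the scatter is expected in this assay although the uncertainty is wide. The expected change is a 1.1-fold higher number from compound 1 to compound 3 (0.02 log units; within the scatter) and this is only a cautious estimate. For compound 3 the estimated value is 2 ug/mL with an expected range from 0.7 ug/mL to 6 ug/mL on this read-out.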

Compound 3, concentration lethal to 50% of the cells: 3.61 ug/mL
Estimate against measurement, compound 3: 1.8-fold (0.26 log units) below; the measured number falls inside the stated range.
By their numbers in this assay, from the lowest: compounds 2, 1 and 3 (each within the scatter of the next, the first and the last beyond it).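

Among the compounds shown here, the carboxy position of the shared core is tested here for the first time, since the earlier pair varied only the saturated chain. In this assay, replacing carboxy with hydroxymethyl gives a 1.9-fold higher number from compound 1 to compound 3 (0.28 log units; within the scatter), so this single change leaves the two compounds level. At least in this pair, the carboxy group is not needed for the toxicity seen in this test, as a compound carrying hydroxymethyl at the same aromatic carbon stays within the usual scatter of compound 1. Nothing available explains this result. Still open, on these data alone, is whether an amide or an amine on this aromatic carbon would stay level too. As far as these compounds go, it is also open whether hydroxymethyl in place of carboxy would give a similar result on the longer chain of compound 2.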